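The source may report more compounds than this note shows. Statements on the series, on what has been measured and on what is new or still open speak of the compounds shown alone.

Measured in an ADME assay on microsomes from liver (Mus musculus) for metabolic stability, read by LC-MS, with a stated time of 30 min, tested at 1 uM; a lower number here means that less of the compound is left, a higher number that more of the compound is left:
- compound 1 `O=C(NCc1ccc(S(=O)(=O)c2ccccc2)cc1)c1ccc2ncncc2c1`: 3.7%
- compound 2 `O=C(NCc1ccc(S(=O)(=O)c2cccc(F)c2)cc1)c1cc2cnccc2[nH]1`: 44%
- compound 3 `O=C(NCc1ccc(S(=O)(=O)N2CCCCC2)cc1)c1cc2cnccc2o1`: 4.6%

Compound 3 cannot be told apart from compound 1 within the usual scatter, while compound 2 lies higher than both, beyond the scatter. Going by the values given here, no two measured compounds differ in only one place, so the series offers no measured step as a guide.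

Compound 4 `O=C(NCc1ccc(S(=O)(=O)N2CCCCC2)cc1)c1cc2ccncc2o1` has the same atoms as compound 3, joined differently: a group of 9 heavy atoms (7 carbon, 1 nitrogen, 1 oxygen; one five-membered aromatic ring with 1 hetero atom, one six-membered aromatic ring with 1 hetero atom) in place of a group of 9 heavy atoms (7 carbon, 1 nitrogen, 1 oxygen; one five-membered aromatic ring with 1 hetero atom, one six-membered aromatic ring with 1 hetero atom), on a carbonyl carbon. The change sits on a carbonyl carbon, and the rest of the molecule stays as it is. Compound 2 differs from compound 3 in more than one place, so its value says little about this change. The closest reference is compound 3 itself at 4.6%, and no shift beyond the scatter is expected in this assay. The expected change is small: a number 1.4 percentage points higher from compound 3 to compound 4 (within the scatter). For compound 4 the estimated value is 6%, with an expected range of 2% to 16%.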

Compound 4, percent of the compound remaining: 0.14%
Compound 4: the middle estimate sits 5.9 percentage points above what was measured; measured number outside the range, below it.
By their numbers in this assay, from the lowest: compounds 4, 1 and 3 (each within the scatter of the next); then compound 2.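

In this assay, rejoining the same atoms within the group on the carbonyl carbon gives a number 4.5 percentage points lower from compound 3 to compound 4 (within the scatter). Going by these compounds alone, this is the first step that can be read at a single place, and it shows that this rearrangement, with the counted rings, hydrogen-bond donors and hydrogen-bond acceptors unchanged, does not move the number beyond the scatter. Nothing on hand bears on why the pair reads this way.

Within the data shown here, compound 2 at 44% is joined to this pair by no single-place step, so what sets its number apart stays open. Also open, as far as these compounds go, is how this assay would read with an amine or a carboxylic acid added to the group on the carbonyl carbon.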